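The compounds below may be only part of what the source reports. "The series", "measured", "known", "first", "only" and "open" are said of these compounds alone.

Measured so far:
- compound 1 `COc1ccc(/C=C2\CCC/C(=C\c3ccccc3Br)C2=O)cc1OC`: 8400 nM
- compound 2 `COc1cc(/C=C2\CCC/C(=C\c3ccc(OC)c(OC)c3)C2=O)ccc1O`: 4600 nM

Within the data shown here, in a functional assay on HT-1080 cells (Homo sapiens) for cytotoxicity, read by MTT assay, with a stated time of 72 h (a lower number here means a stronger inhibitor, a higher number a weaker inhibitor), compound 2 gives 4600 nM, and only one other compound is available for comparison. Among the measured compounds shown here, the one measured step, a 1.8-fold lower number from compound 1 to compound 2 (0.26 log units; within the scatter), puts 4-hydroxy-3-methoxyphenyl in place of 2-bromophenyl, so the two values cannot be told apart.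

Compound 3 `COc1ccc(/C=C2\CCC/C(=C\c3ccc(O)c(O)c3)C2=O)cc1OC` is made from compound 2 on paper by one small edit: hydrogen in place of methyl on an oxygen on an aromatic ring. Hydrogen replaces methyl on an oxygen on an aromatic ring, turning methoxy into hydroxy and 4-hydroxy-3-methoxyphenyl into 3,4-dihydroxyphenyl.

For the measured compounds named here, no measured step makes this same change. The nearest evidence is the step of a 1.8-fold lower number from compound 1 to compound 2 (0.26 log units; within the scatter), a different swap that stayed within the scatter. The expected result is therefore no shift beyond the scatter, namely a 1.2-fold lower number from compound 2 to compound 3 (0.06 log units; within the scatter). For compound 3 the estimated value is 4000 nM, with an expected range of 1300 nM to 12000 nM.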

Compound 3, half-maximal inhibitory concentration: 4200 nM
The estimate for compound 3 lay 1.1-fold (0.02 log units) below the measured number; the range from low to high includes it.
By their numbers in this assay, from the lowest: compounds 3, 2 and 1 (each within the scatter of the next).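

In this assay, among these compounds, the oxygen on the aromatic ring can carry either methyl or hydrogen with no difference that can be read: the edit from methoxy to hydroxy gives a 1.1-fold lower number from compound 2 to compound 3 (0.04 log units; within the scatter) and is the first direct test of this change. The wider swap to 3,4-dihydroxyphenyl on a double-bonded chain carbon bound to a double-bonded ring carbon gives a 2.0-fold lower number from compound 1 to compound 3 (0.30 log units; within the scatter) and also stays within the scatter, so none of the three compounds can be separated from its neighbour by these steps. No supporting measurement is available to explain this flat result.

As far as these compounds go, what an amine, a carboxylic acid or a longer chain on that oxygen would do in this assay stays open. So does whether any change at this place can move the number beyond the scatter.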